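Pentyl-to-heptyl chain extension in the bromophenyl imidazole series

This account rests on a few compounds, and the source may have more. Where it says the series, first, only, none or still open, it means among the compounds named here.

Measured so far:
compound 1 `CCCCCc1nc(N)n(CC(=O)Nc2ccccc2)c1-c1ccccc1Br`: 40600 nM
compound 2 `CCCCCc1nc(N)n(CC(=O)Nc2ccc(C)cc2)c1-c1ccccc1Br`: 5600 nM

In a functional assay on MIA PaCa-2 cells (Homo sapiens) for antiproliferative activity, read by MTT assay, with a stated time of 48 h (a lower number here means a stronger inhibitor, a higher number a weaker inhibitor), compound 2 gives 5600 nM, the lowest of the two numbers; its nearest neighbour is compound 1, and the step of a 7.3-fold lower number from compound 1 to compound 2 (0.86 log units; beyond the scatter) lies beyond the scatter. Compound 3 `CCCCCCCc1nc(N)n(CC(=O)Nc2ccc(C)cc2)c1-c1ccccc1Br` is not yet measured. It differs from compound 2 by ethyl in place of hydrogen on a saturated chain carbon, five bonds along the chain from an aromatic carbon, that is, the pentyl chain on the shared core becomes a heptyl chain. Among the measured compounds shown here, the only measured step, a 7.3-fold lower number from compound 1 to compound 2 (0.86 log units; beyond the scatter), concerns a methyl on the anilide ring and does not touch the chain, so nothing measured bears directly on this change. For compound 3 the estimate is therefore no step beyond the scatter, no change at the digits printed from compound 2 to compound 3 (within the scatter), with a wide range to reflect the missing precedent. Compound 3 is expected to give about 5600 nM, within 1800 nM to 17000 nM.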

Compound 3, half-maximal inhibitory concentration: 7000 nM
Beside the measured number, compound 3's estimate is 1.3-fold (0.10 log units) below it, and the stated range covers the measured number.
By their numbers in this assay, from the lowest: compounds 2 and 3 (each within the scatter of the next); then compound 1.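

In this assay the heptyl chain of compound 3 and the pentyl chain of compound 2 cannot be told apart, with a 1.3-fold higher number from compound 2 to compound 3 (0.10 log units; within the scatter) on the shared core. Among the compounds shown here, this is the first reading at the saturated chain: ethyl in place of hydrogen, five bonds along the chain from an aromatic carbon, stays within the scatter, whereas the earlier step on the anilide ring, a 7.3-fold lower number from compound 1 to compound 2 (0.86 log units; beyond the scatter), lies beyond it. Nothing at hand accounts for this result.

As far as these compounds go, whether a propyl chain, a chain longer than heptyl or a chain ending in an amine would also stay within the scatter remains open. Also open, from the compounds shown here alone, is whether the heptyl chain would read the same without the methyl on the anilide ring, since only the pentyl chain has been seen in that setting.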